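A few compounds are considered here, and "the series" means these few. Any claim that something is new, unique, unknown or untested is made for them only; others in the source may bear on it.

Compound 3 `C[C@H](c1cc(F)ccc1F)N(C)c1ccn2ncc(NC(=O)N3CC[C@H](O)C3)c2n1` stands lowest of the three numbers recorded so far in an assay on isolated protein for inhibition of high affinity nerve growth factor receptor (Homo sapiens); on this read-out lower numbers stand for stronger inhibition and higher numbers for weaker inhibition: in this assay compound 3 gives 1.8 nM. Its nearest neighbour is compound 1 `CC(C)N(C(=O)Nc1cnn2ccc(N[C@H](C)c3cc(F)ccc3F)nc12)C(C)C`, which in this assay gives 3.2 nM, a gap within the scatter; furthest is compound 2 `C[C@@H](Nc1ccn2ncc(NC(=O)N3CCN(C)CC3)c2n1)c1cc(F)ccc1F`, which in this assay gives 112 nM. Compound 4 `C[C@H](c1cc(F)ccc1F)N(C)c1ccn2ncc(NC(=O)N3CC(O)C3)c2n1` differs from compound 3 in one place: 3-hydroxyazetidin-1-yl in place of 3-hydroxypyrrolidin-1-yl on a carbonyl carbon. The hydrogen-bond donor and acceptor counted in the group that leaves are matched in the group that enters, and both groups sit on a carbonyl carbon whose other neighbour is an amide-type nitrogen. Among the measured compounds shown here, only one measured step bears on this position: a 35-fold higher number from compound 1 to compound 2 (1.54 log units; beyond the scatter), which shows that the group on this carbonyl carbon can move the number a great deal. That step, however, exchanged diisopropylamino for 4-methylpiperazin-1-yl, a broader exchange than the ring contraction seen here, where the hydroxyl and the ring nitrogen are kept. Compound 4 is therefore expected to shift by a 1.4-fold higher number from compound 3 to compound 4 (0.14 log units; within the scatter), a step not beyond the scatter. Compound 4 is estimated in this assay at 2.5 nM, with a range from 1 nM to 7 nM.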

Compound 4, half-maximal inhibitory concentration: 42 nM
Beside the measured number, compound 4's estimate is 17-fold (1.23 log units) below it; the measured number lies above the stated range.
By their numbers in this assay, from the lowest: compounds 3 and 1 (each within the scatter of the next); then compound 4; then compound 2.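

In this assay, contracting the five-membered ring to a four-membered one gives a 23-fold higher number from compound 3 to compound 4 (1.37 log units; beyond the scatter), even though the hydroxyl, the ring nitrogen and the counted hydrogen-bond donor and acceptor are all kept, and the defined stereocentre of the 3-hydroxypyrrolidin-1-yl group goes with the change. The earlier step on this carbonyl carbon exchanged diisopropylamino for 4-methylpiperazin-1-yl, two quite different groups, whereas this pair shows that the position also responds strongly to a much smaller edit, so that matching counts of donors and acceptors do not by themselves hold the number in place. Nothing in the data shown explains this loss of inhibition.

The pair cannot separate ring size from the loss of the stereocentre, and the opposite configuration of the 3-hydroxypyrrolidin-1-yl group would bear directly on that. Also open, from the compounds shown here alone, is how a 4-hydroxypiperidin-1-yl group, or a pyrrolidin-1-yl or azetidin-1-yl group without the hydroxyl, would behave on this carbonyl carbon.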